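The source may report more compounds than this note shows. Statements on the series, on what has been measured and on what is new or still open speak of the compounds shown alone.

Working notes on the series. Among the compounds with values here, in a functional assay on HepG2 cells (Homo sapiens) for antiproliferative activity, read by CCK-8 assay, with a stated time of 72 h (on this read-out higher numbers stand for weaker inhibition and lower numbers for stronger inhibition), compound 3 (`O=C(NO)c1ccc(COc2ccccc2)cc1`) gives 29600 nM, the higher of the two actual numbers so far, and compound 1 (`C/C(=N\O)c1ccc(OCc2ccc(C(=O)NO)cc2)cc1`) gives 7770 nM. Compound 2 (`Nc1ccccc1NC(=O)c1ccc(COc2ccc([N+](=O)[O-])cc2)cc1`) gives > 32000 nM, which is a limit and not a number.

The next change leads to compound 4 (`Nc1ccccc1NC(=O)c1ccc(COc2ccccc2)cc1`): 2-aminophenyl in place of hydroxy on an amide-type nitrogen. In words, 2-aminophenyl comes in place of hydroxy on an amide-type nitrogen.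

Within the data shown here, the only measured step is a 3.8-fold higher number from compound 1 to compound 3 (0.58 log units; beyond the scatter). It is modest but beyond the scatter, and it concerns an aromatic carbon, not the amide-type nitrogen, so it gives no direct size for this change. Among the measured compounds shown here, the closest evidence is compound 2, the only measured compound with 2-aminophenyl on the amide-type nitrogen, at > 32000 nM, again a limit. That points to weak inhibition, with no sign of a gain over compound 3.

No step beyond the scatter is therefore expected, with any movement more likely towards a higher number. The expected step is a 1.2-fold higher number from compound 3 to compound 4 (0.07 log units; within the scatter). The reading may also end at the limit of > 32000 nM in this assay, at which 1 of the 3 values shown sits, and this outcome is expected about as often as a number. The estimate for compound 4 is 35000 nM, with an expected range of 15000 nM to 80000 nM.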

Compound 4, half-maximal inhibitory concentration: 6700 nM
Compound 4: the middle estimate sits 5.2-fold (0.72 log units) above what was measured, outside the stated range (below it).
By their numbers in this assay, from the lowest: compounds 4 and 1 (each within the scatter of the next); then compound 3. At a limit, above all of these: compound 2.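

In this assay, within the data shown here, the first direct reading of this change on the amide-type nitrogen is a 4.4-fold lower number from compound 3 to compound 4 (0.65 log units; beyond the scatter) in favour of 2-aminophenyl over hydroxy, so this position accepts the larger group and the pair moves towards stronger inhibition by a modest amount. With 2-aminophenyl held on that nitrogen, the aromatic carbon also counts, since hydrogen in place of nitro gives an at least 4.7-fold lower number from compound 2 to compound 4 (0.67 log units; beyond the scatter) as a bound only. As far as these compounds go, compound 2 stands at a limit and not a number, so the full size of that step stays unknown: the limit of > 32000 nM in this assay, at which 1 of the 4 values shown sits.

The compounds shown do not tell whether 2-aminophenyl gives the same gain over hydroxy when the aromatic carbon carries the group present in compound 1, or when it carries an amine or a carboxylic acid. They also leave open whether the amino group of 2-aminophenyl is needed, as plain phenyl or 2-hydroxyphenyl on the amide-type nitrogen would show.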